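This account rests on a few compounds, and the source may have more. Where it says the series, first, only, none or still open, it means among the compounds named here.

Working notes on the series.

Of the compounds shown here, three of this set have been measured in an assay on isolated protein for displacement of a labelled ligand from melanin-concentrating hormone receptor 1 (Homo sapiens); a higher number here means a weaker inhibitor, a lower number a stronger inhibitor. Compound 1, `CCCc1cc(N)c2cc(NC(=O)CCc3ccccc3)ccc2n1`, gives 8300 nM. Compound 2, `CCCc1cc(N)c2cc(NC(=O)/C=C/c3ccc(CC)cc3)ccc2n1`, gives 1.4 nM. Compound 3, `CCCc1cc(NC2CC2)c2cc(NC(=O)/C=C/c3ccc(C(F)(F)F)cc3)ccc2n1`, gives 40 nM. Compound 2 thus stands at the lowest number of the three, with compound 3 as its nearest neighbour and compound 1 far away from both; compound 1 and compound 3 each differ from compound 2 in more than one place, so no single-point step can be read out of them.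

The next compound, compound 4, `CCCc1cc(N)c2cc(NC(=O)/C=C/c3ccc(C(C)C)cc3)ccc2n1`, has not yet been measured in this assay. It differs from compound 2 in one place only: methyl in place of hydrogen on a saturated chain carbon bound to an aromatic carbon and a saturated chain carbon. Cut one bond further out, this reads as ethyl to isopropyl, that is, 4-ethylphenyl to 4-isopropylphenyl on the far end of the amide side chain.

For the measured compounds named here, no measured pair in this set isolates a change of this kind, so the expectation rests on the closeness of compound 4 to compound 2 alone. Because compound 2 gives 1.4 nM, compound 4 is expected to stay close, with a step of a 1.4-fold higher number from compound 2 to compound 4 (0.15 log units; within the scatter) that should not go beyond the scatter. The estimate for compound 4 in this assay is 2 nM, within a range from 0.5 nM to 10 nM.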

Compound 4, half-maximal inhibitory concentration: 2.9 nM
Beside the measured number, compound 4's estimate is 1.5-fold (0.16 log units) below it, within the range that was stated.
By their numbers in this assay, from the lowest: compound 2; then compound 4; then compound 3; then compound 1.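

For the compounds shown here, compound 4 supplies the only step in this set that changes a single place, and it gives a direct reading of this position in this assay: methyl in place of hydrogen on a saturated chain carbon bound to an aromatic carbon and a saturated chain carbon gives a 2.1-fold higher number from compound 2 to compound 4 (0.32 log units; beyond the scatter). The step is modest but printed as beyond the scatter, so going from 4-ethylphenyl to 4-isopropylphenyl is a real though small loss, and compound 4 still holds a low number at 2.9 nM in this assay. Nothing available accounts for the size of this step.

One step cannot show how this position responds to other changes, such as tert-butyl, a cyclopropyl ring, a longer chain, or a hydroxyl or amine on the same carbon. Going by these compounds, the other gaps in the set, including those to compound 1 and compound 3, cannot be read as steps, so the separate contributions of the saturated linker, the cyclopropylamine and the trifluoromethyl group remain open.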